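The source may report more compounds than this note shows. Statements on the series, on what has been measured and on what is new or still open speak of the compounds shown alone.

Compound 3 `Cc1c(OC[C@@H](C)COc2ccc(C(=O)O)cc2F)ccc(C(=O)CC(C)(C)C)c1O` gives 1300 nM in an assay for positive allosteric modulation of metabotropic glutamate receptor 3 (Rattus norvegicus) (a higher number here means that more compound is needed for the effect, a lower number that less compound is needed), the lowest of the two numbers, though its gap to compound 2 `Cc1c(OC[C@@H](C)COc2ccc(Cl)c(C(=O)O)c2)ccc(C(=O)CC(C)(C)C)c1O`, which gives 2200 nM, is only a 1.7-fold lower number from compound 2 to compound 3 (0.23 log units; within the scatter). Compound 1 `Cc1ccc(OC[C@H](C)COc2ccc(C(=O)CC(C)(C)C)c(O)c2C)cc1C(=O)O` gives no number in this assay but only a limit, > 10000 nM. Compound 4 `Cc1c(OC[C@@H](C)COc2ccc(C(=O)O)cc2Cl)ccc(C(=O)CC(C)(C)C)c1O` differs from compound 3 by chloro in place of fluoro on an aromatic carbon. For the measured compounds named here, no measured step exchanges these two halogens directly. The steps that come nearest are an at least 4.5-fold lower number from compound 1 to compound 2 (0.65 log units; beyond the scatter) and an at least 7.6-fold lower number from compound 1 to compound 3 (0.88 log units; beyond the scatter), both read against a limit (the limit of > 10000 nM in this assay, at which 1 of the 3 values shown sits), together with the small 1.7-fold lower number from compound 2 to compound 3 (0.23 log units; within the scatter). Compound 4 is therefore expected to show a step of a 1.1-fold lower number from compound 3 to compound 4 (0.03 log units; within the scatter), nothing beyond the scatter. The estimate for compound 4 is 1200 nM, within a range of 500 nM to 3000 nM.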

Compound 4, half-maximal effective concentration: 1650 nM
The estimate for compound 4 lay 1.4-fold (0.14 log units) below the measured number; the range from low to high includes it.
By their numbers in this assay, from the lowest: compounds 3, 4 and 2 (each within the scatter of the next). At a limit, above all of these: compound 1.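

In this assay, the direct exchange of the two halogens on this aromatic carbon, ortho to a large group, gives a 1.3-fold higher number from compound 3 to compound 4 (0.10 log units; within the scatter), so fluoro and chloro cannot be told apart here. Replacing 3-carboxy-4-chlorophenyl with 4-carboxy-2-chlorophenyl gives a 1.3-fold lower number from compound 2 to compound 4 (0.12 log units; within the scatter), which also separates nothing. The step to 4-carboxy-2-chlorophenyl gives an at least 6.0-fold lower number from compound 1 to compound 4 (0.78 log units; beyond the scatter), with compound 1 a limit and not a number: the limit of > 10000 nM in this assay, at which 1 of the 4 values shown sits.

The compounds shown leave open what a methoxy group, a nitrile or plain hydrogen would do at this position. They also leave open whether an amide could stand in place of the carboxy group.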